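Swapping a chlorothiazole for a bromophenyl on the sulfonyl

This account rests on a few compounds, and the source may have more. Where it says the series, first, only, none or still open, it means among the compounds named here.

Compound 1 `COc1ccccc1-c1ccc(S(=O)(=O)N2CCC(N3CCC(C)CC3)CC2)cc1`: > 5000 nM
Compound 2 `CC1CCN(C2CCN(S(=O)(=O)c3cnc(Cl)s3)CC2)CC1`: > 10000 nM
Compound 3 `CC1CCN(C2CCN(S(=O)(=O)c3sc(Cl)nc3C3CC3)CC2)CC1`: > 10000 nM

All three measured compounds share one core and differ only in the aromatic group on the sulfonyl sulfur. In an ADME assay on HCT-116 cells (Homo sapiens) for cytotoxicity, read by CellTiter-Glo, with a stated time of 72 h (on this read-out higher numbers stand for weaker inhibition and lower numbers for stronger inhibition), compound 2 gives > 10000 nM, which is a limit of the assay and not a number. Compound 3 gives > 10000 nM in this assay, likewise a limit. Compound 1 gives > 5000 nM, also a limit. Compound 2 thus stands at the higher of the two boundaries recorded, together with compound 3, while compound 1 sits at the lower boundary; since all are limits, the three cannot be ordered. Within the data shown here, the single step between measured compounds, a step that the two limits leave unreadable from compound 2 to compound 3, is unreadable for the same reason.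

Compound 4 `CC1CCN(C2CCN(S(=O)(=O)c3cccc(Br)c3)CC2)CC1` differs from compound 2 by 3-bromophenyl in place of 2-chloro-1,3-thiazol-5-yl on a sulfonyl sulfur. Among the measured compounds shown here, no measured step covers this exchange. What bears on it is the limit of > 10000 nM in this assay, at which 2 of the 3 values shown sit, together with the limit of > 5000 nM in this assay, at which 1 of the 3 values shown sits: three different aromatic groups on the sulfonyl sulfur all gave no readable inhibition. The step that the limit leaves unreadable from compound 2 to compound 4 is therefore expected to show nothing beyond the scatter. Compound 4 is estimated at 15000 nM, with a range from 5000 nM to 50000 nM, and is expected most likely to be reported as a limit once more.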

Compound 4, half-maximal inhibitory concentration: > 5000 nM
Compound 4 ended at the assay's limit; the forecaster's own chance of this, stated with the estimate: 85%; the middle value does not contradict the limit.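

In this assay compound 4 gives > 5000 nM, which is a limit of the assay and not a number. Compound 2 also stands at a limit, so no new step can be read between compound 2 and compound 4. The compounds shown leave open whether any aromatic group on the sulfonyl sulfur gives a readable inhibition, and how such groups would rank.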